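This account rests on a few compounds, and the source may have more. Where it says the series, first, only, none or still open, it means among the compounds named here.

Of the compounds shown here, two built on one shared core have been measured in a functional assay on HepG2 cells (Homo sapiens) for cytotoxicity, read by MTT assay, with a stated time of 48 h; a higher number here means a weaker inhibitor, a lower number a stronger inhibitor. Compound 1 `Cc1ccc(C(=O)N2N=C(c3cc4ccccc4oc3=O)CC2c2ccccc2)cc1` carries a 4-methylphenyl group on its carbonyl carbon, and in this assay compound 1 gives 52300 nM. Compound 2 `O=C(CCl)N1N=C(c2cc3ccccc3oc2=O)CC1c1ccccc1` has a chloromethyl group in that place, and in this assay compound 2 gives 2980 nM. Among the measured compounds shown here, the single measured step reads an 18-fold lower number from compound 1 to compound 2 (1.24 log units; beyond the scatter). On the numbers shown, compound 2 therefore stands at the lowest value of the two, with compound 1 as its only and distant neighbour.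

Compound 3 `O=C(c1ccccc1Cl)N1N=C(c2cc3ccccc3oc2=O)CC1c1ccccc1` is not yet measured. It differs from compound 2 by 2-chlorophenyl in place of chloromethyl on a carbonyl carbon. For the measured compounds named here, the one measured step that touches this place, an 18-fold lower number from compound 1 to compound 2 (1.24 log units; beyond the scatter), shows that trading an aromatic ring on the carbonyl carbon for chloromethyl brought a large fall in the number; compound 3 undoes that trade and puts an aromatic ring back, so a higher number than that of compound 2 is expected, by a step of about an 8.4-fold higher number from compound 2 to compound 3 (0.92 log units; beyond the scatter). Compound 3 is estimated at 25000 nM, with a range from 8000 nM to 70000 nM.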

Compound 3, half-maximal inhibitory concentration: 5440 nM
Estimate against measurement, compound 3: 4.6-fold (0.66 log units) above; the measured number lies below the stated range.
By their numbers in this assay, from the lowest: compounds 2 and 3 (each within the scatter of the next); then compound 1.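

In this assay, the step of a 1.8-fold higher number from compound 2 to compound 3 (0.26 log units; within the scatter) stays within the scatter, so at this place on the carbonyl carbon 2-chlorophenyl and chloromethyl cannot be told apart, and having an aromatic ring there does not by itself give a number like that of compound 1. The identity of the aromatic group matters instead: the step of a 9.6-fold lower number from compound 1 to compound 3 (0.98 log units; beyond the scatter) lies beyond the scatter, which ties the high number of compound 1 to 4-methylphenyl in particular, not to aromatic groups as a whole. No measured information on these compounds gives a reason for this difference.

Compound 2 and compound 3 each carry a chlorine in this group and compound 1 does not, but 2-chlorophenyl and 4-methylphenyl differ in both the atom attached to the ring and the name of its place, so these three compounds cannot separate the two. Plain phenyl, 4-chlorophenyl and 2-methylphenyl would pull those two features apart, while a chain ending in an amine would test whether this place accepts a very different kind of group.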